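Compound 3: a 3-iodophenyl step from a limit

The source may report more compounds than this note shows. Statements on the series, on what has been measured and on what is new or still open speak of the compounds shown alone.

Compound 1 (`O=C(CCc1cccc2c1B(O)OC2)NCc1ccccc1`) gives > 100000 nM in a functional assay on HCT-116 cells (Homo sapiens) for antiproliferative activity, read by MTT assay, with a stated time of 72 h (on this read-out lower numbers stand for stronger inhibition and higher numbers for weaker inhibition), and this reading is a limit, not a number. Compound 2 (`CCOC(=O)c1ccc(NC(=O)CCc2cccc3c2B(O)OC3)cc1`) gives > 100000 nM in this assay, which is likewise a limit. The series therefore stands at the limit of > 100000 nM in this assay, at which 2 of the 2 values shown sit, with no measured number yet, and compound 1 has no position beyond that limit.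

The next compound is compound 3 (`O=C(CCc1cccc2c1B(O)OC2)Nc1cccc(I)c1`). The change is 3-iodophenyl in place of benzyl on an amide-type nitrogen and it places 3-iodophenyl in the position of benzyl on an amide-type nitrogen, while the rest of the core of compound 1 stays the same.

Going by the values given here, no measured step gives a size for this kind of change, so the expectation is cautious. The expected step of an at least 1.4-fold lower number from compound 1 to compound 3 (0.15 log units; that floor lies within the scatter) in this assay is small, toward stronger inhibition if it shows at all, and it may stay within the scatter. Another limit reading is quite possible. Compound 3 is expected at 70000 nM with an estimated range from 20000 nM to 100000 nM in this assay when a number is reported.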

Compound 3, half-maximal inhibitory concentration: 2300 nM
Beside the measured number, compound 3's estimate is 30-fold (1.48 log units) above it; measured number below the stated range.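

Replacing benzyl with 3-iodophenyl on an amide-type nitrogen gives an at least 43-fold lower number from compound 1 to compound 3 (1.63 log units; beyond the scatter) in this assay, so the group on this nitrogen can move a compound from a limit reading to a measured number while the rest of the core of compound 1 stays the same. A phenyl ring joined directly to this nitrogen is not enough on its own: compound 2, which has an ethyl ester on such a ring, gives > 100000 nM, and this reading is a limit. Since compound 1 is itself a limit, the step gives only a floor for the size of the change, and the measured number in compound 3 stands alone in the series: the limit of > 100000 nM in this assay, at which 2 of the 3 values shown sit.

The step changes how the ring is joined to the nitrogen and adds iodine at the same time, and the compounds shown do not separate these two parts. On these data alone, whether a plain phenyl, a 3-bromophenyl or a 3-aminophenyl on the same nitrogen would also give a measured number remains open, as does the effect of moving the iodine to another place on the ring.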